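Quinoline thiosemicarbazones: removing the para cyano group

The compounds below may be only part of what the source reports. "The series", "measured", "known", "first", "only" and "open" are said of these compounds alone.

Measured compounds:
- compound 1 `N#Cc1ccc(NC(=S)N/N=C/c2ccc3ccccc3n2)cc1`: 4660 nM
- compound 2 `Cc1csc2sc(/C=N/NC(N)=S)c(C)c12`: > 100000 nM
- compound 3 `NC(=S)N/N=C/c1cc2cccnc2s1`: > 100000 nM

Going by the values given here, in a functional assay on HL-60 cells (Homo sapiens) for antiproliferative activity, read by sulforhodamine B assay, with a stated time of 72 h (a higher number here means a weaker inhibitor, a lower number a stronger inhibitor), compound 1 gives 4660 nM, the only number in the set. For compound 2 the result is a limit of the assay, > 100000 nM. For compound 3 the result is likewise a limit, > 100000 nM. Two of the three results therefore sit at the limit of > 100000 nM in this assay, at which 2 of the 3 values shown sit, and compound 1 is the sole reference point for any step.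

Compound 4 `S=C(N/N=C/c1ccc2ccccc2n1)Nc1ccccc1` has not yet been measured. It differs from compound 1 by hydrogen in place of cyano on an aromatic carbon.

Among the compounds with values here, no measured pair differs in one place, so the size of this step cannot be read from the data. The change is small, a single heavy-atom group leaving; a step of modest size, most likely within or just beyond the usual scatter, is expected, if anything toward a weaker inhibitor.

Compound 4 is therefore expected to give 7000 nM in this assay, with a plausible range from 2500 nM to 20000 nM, which means an expected step of a 1.5-fold higher number from compound 1 to compound 4 (0.18 log units; within the scatter).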

Compound 4, half-maximal inhibitory concentration: 9130 nM
Beside the measured number, compound 4's estimate is 1.3-fold (0.12 log units) below it; measured number inside the range.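

Going by these compounds alone, the 4-cyanophenyl to phenyl change gives the first readable step: in this assay it is a 2.0-fold higher number from compound 1 to compound 4 (0.29 log units; within the scatter). On an aromatic carbon para to a large group, removing the cyano therefore leaves the result within the scatter, and the shared core keeps a measurable value without the nitrile. No measured property in the set bears on this step.

From the compounds shown here alone, whether another group at this position, such as an amine or a carboxylic acid, would give a step beyond the scatter stays open. Within the data shown here, compounds 2 and 3 differ from compound 1 and compound 4 in more than one place, so no step to either can be read, and what the rest of the core contributes remains unresolved.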